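Methoxy Count on the Sulfonate Aryl Ring

The source may report more compounds than this note shows. Statements on the series, on what has been measured and on what is new or still open speak of the compounds shown alone.

Values in a functional assay on HT-29 cells (Homo sapiens) for antiproliferative activity, read by sulforhodamine B assay, with a stated time of 48 h; a lower number here means a stronger inhibitor, a higher number a weaker inhibitor:
compound 1 `COc1ccc(OS(=O)(=O)c2ccc(N3CCN(C)C3=O)cc2)cc1OC`: 12000 nM
compound 3 `CCN1CCN(c2ccc(S(=O)(=O)Oc3cc(OC)cc(OC)c3)cc2)C1=O`: 4300 nM
compound 2 `COc1ccc(OS(=O)(=O)c2ccc(N3CCN(C)C3=O)cc2)cc1`: reports only a limit, > 100000 nM

Compound 3 stands lowest of the two numbers. The change from compound 2 to compound 1 is methoxy in place of hydrogen on an aromatic carbon, and the step it made is an at least 8.3-fold lower number from compound 2 to compound 1 (0.92 log units; beyond the scatter). Compound 3 and compound 2 differ in their cores; that difference is not broken down here. Compound 4 `CCN1CCN(c2ccc(S(=O)(=O)Oc3cc(OC)c(OC)c(OC)c3)cc2)C1=O` is not yet measured in this assay and arises from compound 3 by methoxy in place of hydrogen on an aromatic carbon. This is the same kind of change as from compound 2 to compound 1, though the places differ: there the methoxy is ortho to a methoxy group and meta to a large group, here ortho to two methoxy groups and para to a large group. Resting on an at least 8.3-fold lower number from compound 2 to compound 1 (0.92 log units; beyond the scatter), a step of a 2.9-fold lower number from compound 3 to compound 4 (0.46 log units; beyond the scatter) is expected. Compound 4 is estimated at 1500 nM, between 300 nM and 6000 nM.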

Compound 4, half-maximal inhibitory concentration: 640 nM
Beside the measured number, compound 4's estimate is 2.3-fold (0.37 log units) above it; measured number inside the range.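

In this assay, methoxy in place of hydrogen on an aromatic carbon gives a 6.7-fold lower number from compound 3 to compound 4 (0.83 log units; beyond the scatter), so the lower number seen on one core also appears on the second, here with the methoxy ortho to two methoxy groups. Compound 2 reports > 100000 nM, which is a limit of the assay and not a number. The two pairs show the same direction on both cores, but they do not establish an equal size of step or a rule for other cores: the same change on two cores in this assay, an at least 8.3-fold lower number (0.92 log units; beyond the scatter) from compound 2 to compound 1 and a 6.7-fold lower number (0.83 log units; beyond the scatter) from compound 3 to compound 4; the limit leaves it open whether they differ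

As far as these compounds go, whether a hydroxy group or an amine in place of the added methoxy of compound 4 would give a similar step remains open. So does the effect of a longer chain in place of the ethyl group of compound 4.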